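Stretching the Sulfonamide Chain in a Cytotoxicity Series

The source may hold more compounds than are shown below. What is called first, only, known or untested is meant among the compounds shown, and "the series" means these compounds.

Within the data shown here, two compounds sharing one core were examined in a functional assay on HCT-116 cells (Homo sapiens) for cytotoxicity, read by MTT assay, with a stated time of 72 h (a higher number here means a weaker inhibitor, a lower number a stronger inhibitor), and only one has a number. For compound 1 `C[C@@H](CO)Nc1nc(C(=O)NCc2ccc(F)cc2)c(O)c2ncccc12` the entry is "not determined" (no result reported) and offers no comparison. Among the measured compounds shown here, compound 2 `CS(=O)(=O)NCCCN(c1nc(C(=O)NCc2ccc(F)cc2)c(O)c2ncccc12)S(C)(=O)=O` gives 15000 nM as the sole value in the set, so it can be ranked against nothing. Compound 3 `CS(=O)(=O)NCCCCCCN(c1nc(C(=O)NCc2ccc(F)cc2)c(O)c2ncccc12)S(C)(=O)=O` awaits measurement. Its difference from compound 2 is counted as 3-(methanesulfonamido)propyl in place of methanesulfonamido on a saturated chain carbon, three bonds along the chain from a sulfonamide nitrogen and amounts to 3-(methanesulfonamido)propyl in place of methanesulfonamido on a saturated chain carbon, three bonds along the chain from a sulfonamide nitrogen. For the measured compounds named here, no measured step gauges such a change, so the expectation rests on compound 2 at 15000 nM alone, and no shift beyond the scatter in this assay is foreseen in either direction. The expected move is a 1.3-fold lower number from compound 2 to compound 3 (0.10 log units; within the scatter) and no more. For compound 3 the estimated value is 12000 nM with 4000 nM to 30000 nM as the expected range.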

Compound 3, half-maximal inhibitory concentration: 3000 nM
Estimate against measurement, compound 3: 4.0-fold (0.60 log units) above; the measured number lies below the stated range.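

In this assay, putting 3-(methanesulfonamido)propyl in place of methanesulfonamido on a saturated chain carbon, three bonds along the chain from a sulfonamide nitrogen, gives a 5.0-fold lower number from compound 2 to compound 3 (0.70 log units; beyond the scatter). This shows that lengthening the chain at this place can move the cytotoxicity number beyond the usual scatter, towards a stronger inhibitor, though the step is modest and a single pair sets no trend. No measured information accompanies the result that would explain the shift.

From the compounds shown here alone, it remains open whether the number changes evenly through chains of intermediate length or keeps falling with a still longer chain. Also unresolved is whether the gain depends on the methanesulfonamido group, which an amine or a carboxylic acid in its place would test.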